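Enlarging the methoxycarbonyl group of compound 3

The source may hold more compounds than are shown below. What is called first, only, known or untested is meant among the compounds shown, and "the series" means these compounds.

Measured in a physicochemical assay for lipophilicity, at pH 7.4; a lower number here means a more polar compound, a higher number a more lipophilic compound:
- compound 1 `CCc1ccc(N(CC(C)C)S(=O)(=O)c2ccc3cc(OCC4CCOCC4)c(C(=O)O)cc3c2)cc1`: 1.77
- compound 2 `CCc1ccc(N(CC(C)C)S(=O)(=O)c2ccc3c(c2)C(=O)CC(C(C)C2CCOCC2)O3)cc1`: 4.93
- compound 3 `CCc1ccc(N(CC(C)C)S(=O)(=O)c2ccc3cc(OCC4CCOCC4)c(C(=O)OC)cc3c2)cc1`: 6.09

Compound 3 stands highest of the three at 6.09. Compound 4 `CCc1ccc(N(CC(C)C)S(=O)(=O)c2ccc3cc(OCC4CCOCC4)c(C(=O)OCC4CCOCC4)cc3c2)cc1` is not yet measured. Its difference from compound 3 is oxan-4-yl in place of hydrogen on a saturated chain carbon bound to an oxygen next to a carbonyl group, so methyl becomes (oxan-4-yl)methyl.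

Among the compounds with values here, the only measured step that bears on this is large: a number 4.32 log units higher from compound 1 to compound 3 (beyond the scatter). It replaced hydrogen, not methyl, so it suggests a direction but no size. A small upward step in this assay is therefore expected, near the usual scatter. The estimated step is a number 0.11 log units higher from compound 3 to compound 4 (within the scatter). For compound 4 the expected value is 6.2, with an estimated range of 5.6 to 6.8.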

Compound 4, distribution coefficient: 6.34
Compound 4: middle estimate off by 0.14 log units, on the low side, within the range that was stated.
By their numbers in this assay, from the lowest: compound 1; then compound 2; then compounds 3 and 4 (each within the scatter of the next).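

In this assay, going from methyl to (oxan-4-yl)methyl on the oxygen next to the carbonyl group gives no change beyond the scatter (a number 0.25 log units higher from compound 3 to compound 4 (within the scatter)). The large gap from the free acid remains with the bigger group (a number 4.57 log units higher from compound 1 to compound 4 (beyond the scatter)), so among these compounds, replacing that hydrogen matters far more than which of these two groups replaces it. No measurement shown here accounts for this.

Going by these compounds, whether an amine or a longer chain in place of oxan-4-yl would shift the number in this assay stays open.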